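A few compounds are considered here, and "the series" means these few. Any claim that something is new, unique, unknown or untested is made for them only; others in the source may bear on it.

Measured in a functional assay on HL-60 cells (Homo sapiens) for cytotoxicity, read by WST assay, with a stated time of 48 h; on this read-out higher numbers stand for an effect only at larger amounts of compound and lower numbers for an effect already at smaller amounts:
- compound 1 `O=C1OC[C@H](Cc2ccccc2)[C@H]1Cc1ccccc1F`: 72000 nM
- compound 2 `CCCCCCCOc1cccc(C[C@H]2C(=O)OC[C@@H]2Cc2ccccc2)c1`: 81000 nM

Compound 2 stands level with compound 1, as the two values lie within the usual scatter of each other. The next compound is compound 3 `O=C1OC[C@H](Cc2ccccc2)[C@H]1Cc1cccc(Cl)c1`, which carries chloro in place of heptyloxy on an aromatic carbon, meta to a large group: chloro in place of heptyloxy on an aromatic carbon. Among the compounds with values here, no step between measured compounds that differ in one place is available, so the size of this change has no direct precedent. Within the data shown here, with compound 1 at 72000 nM and compound 2 at 81000 nM, nothing measured so far points to a large step in this assay. The expected result is a slightly lower number, with no change beyond the scatter: an estimated 1.4-fold lower number from compound 2 to compound 3 (0.13 log units; within the scatter). For compound 3 the expected value is 60000 nM, with an estimated range of 20000 nM to 150000 nM.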

Compound 3, half-maximal effective concentration: 36000 nM
For compound 3 the middle estimate is 1.7-fold (0.22 log units) above the measured one, and the stated range covers the measured number.
By their numbers in this assay, from the lowest: compounds 3, 1 and 2 (each within the scatter of the next, the first and the last beyond it).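

In this assay, within the data shown here, chloro in place of heptyloxy on an aromatic carbon, meta to a large group, gives a 2.3-fold lower number from compound 2 to compound 3 (0.35 log units; beyond the scatter), the first step beyond the scatter, though only a modest one. Setting 3-chlorophenyl in place of 2-fluorophenyl on a saturated chain carbon bound to a saturated ring carbon gives a 2.0-fold lower number from compound 1 to compound 3 (0.30 log units; within the scatter), so this change shows no clear effect on the read-out. Nothing measured here explains either step.

Going by these compounds, whether the lower number of compound 3 follows from the chloro group or simply from the loss of the heptyloxy chain stays open, as this one pair does not separate the two. On these data alone, how a methoxy group, an amine or a carboxylic acid on the same aromatic carbon would read also remains open.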